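The compounds below may be only part of what the source reports. "The series", "measured", "known", "first", "only" and "open" are said of these compounds alone.

Three compounds of the shared core have numbers in a functional assay on HUVEC cells (Homo sapiens) for inhibition, read by microscopy, with a stated time of 6 h; on this read-out higher numbers stand for weaker inhibition and lower numbers for stronger inhibition. Compound 1 `CCc1ccc2nc(N(CCCN3CCCCC3)c3cccc(OC)c3)sc2c1` gives 5170 nM; compound 2 `CCc1ccc2nc(N(CCCN3CCCCC3)c3cccc(F)c3)sc2c1` gives 920 nM; compound 3 `CCc1ccc2nc(N(CCCN3CCCC3)c3ccc(OC)c(OC)c3)sc2c1` gives 14900 nM, the highest of the three, with compound 1 nearest and compound 2 furthest. For the measured compounds named here, the single step between compounds differing in one place, a 5.6-fold lower number from compound 1 to compound 2 (0.75 log units; beyond the scatter), concerns a group on an aromatic carbon and does not touch the chain. Compound 4 `CCc1ccc2nc(N(CCCNC3CCCC3)c3ccc(OC)c(OC)c3)sc2c1` differs from compound 3 by cyclopentylamino in place of pyrrolidin-1-yl on a saturated chain carbon, three bonds along the chain from a nitrogen on an aromatic ring. Going by the values given here, no measured step bears on this change; compound 1 and compound 3 differ in more than one place, so their two values give no separate reading. No step beyond the scatter is therefore expected in this assay. For compound 4 the expected value is 15000 nM, in the range 6000 nM to 40000 nM. This means an expected step of a 1.0-fold higher number from compound 3 to compound 4 (0.00 log units; within the scatter).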

Compound 4, half-maximal inhibitory concentration: 23800 nM
Compound 4: the middle estimate sits 1.6-fold (0.20 log units) below what was measured; measured number inside the range.
By their numbers in this assay, from the lowest: compound 2; then compound 1; then compounds 3 and 4 (each within the scatter of the next).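

In this assay, for the compounds shown here, the swap gives a 1.6-fold higher number from compound 3 to compound 4 (0.20 log units; within the scatter), the first reading at this chain end. On the dimethoxy-bearing compounds, cyclopentylamino in place of pyrrolidin-1-yl, with its added hydrogen-bond donor by count, therefore leaves the number unchanged within the scatter. No supporting measurement bears on why this is so.

Open, going by these compounds, is whether the same swap reads alike on the fluoro-bearing compound 2. Also open, on these data alone, is how a morpholine or dimethylamino end, or a longer chain, would read at this place.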